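Tetrazole for Carboxylic Acid on the Piperidine of Compound 3

A few compounds are considered here, and "the series" means these few. Any claim that something is new, unique, unknown or untested is made for them only; others in the source may bear on it.

Of the compounds shown here, three sharing one core have been measured in an assay on isolated protein for binding affinity to Bombesin receptor subtype-3 (Homo sapiens); a lower number here means a stronger inhibitor, a higher number a weaker inhibitor. Compound 1 `CCC(C)(C)Cc1c[nH]c(CCc2ccc(-c3ccccc3O)cc2)n1` gives 31 nM. Compound 2 `CCC(C)(C)Cc1c[nH]c(CCc2ccc(-c3ccccc3OCC(=O)O)cc2)n1`, which carries a carboxymethyl in place of hydrogen on the ring oxygen, gives 103 nM; the change is a 3.3-fold higher number from compound 1 to compound 2 (0.52 log units; beyond the scatter). Compound 3 `CCC(C)(C)Cc1c[nH]c(CCc2ccc(N3CCCC[C@@H]3C(=O)O)cc2)n1` gives 5.3 nM, the lowest number of the three and thus the strongest binder in this set, reached through a 5.8-fold lower number from compound 1 to compound 3 (0.77 log units; beyond the scatter); its gap to compound 2 is wider still.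

Compound 4 `CCC(C)(C)Cc1c[nH]c(CCc2ccc(N3CCCC[C@@H]3c3nnn[nH]3)cc2)n1` differs from compound 3 in one place: 1H-tetrazol-5-yl in place of carboxy on a saturated ring carbon. Going by the values given here, no measured pair in this set bears directly on this exchange. The steps from compound 1 to compound 2 and from compound 1 to compound 3 were both modest in size and both involved a carboxy group, but neither replaced an acid with a tetrazole, so they set only a rough scale. The exchange keeps one hydrogen-bond donor and adds acceptors, and in this assay the expected step from compound 3 to compound 4 is a 1.5-fold higher number from compound 3 to compound 4 (0.18 log units; within the scatter), small enough to fall near the scatter in either direction. Compound 4 is therefore expected to give about 8 nM, within a range from 2 nM to 30 nM.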

Compound 4, half-maximal inhibitory concentration: 6.2 nM
Compound 4: middle estimate off by 1.3-fold (0.11 log units), on the high side; measured number inside the range.
By their numbers in this assay, from the lowest: compounds 3 and 4 (each within the scatter of the next); then compound 1; then compound 2.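

In this assay, 1H-tetrazol-5-yl in place of carboxy on the saturated ring carbon, next to the ring nitrogen, gives a 1.2-fold higher number from compound 3 to compound 4 (0.07 log units; within the scatter), so the two compounds cannot be told apart in this assay. Going by these compounds alone, the earlier steps changed the whole group on the aromatic carbon, whereas this one is the first to change only the group on the six-membered non-aromatic ring, and it shows that the number holds when carboxy, with 3 heavy atoms and no ring, gives way to a five-membered aromatic ring with 5 heavy atoms, 4 of them nitrogen. Nothing available explains why the two groups give numbers within the scatter of each other.

As far as these compounds go, what a primary amide, a methyl ester or a hydroxymethyl group would give on this same ring carbon remains open, and so does whether either group is needed there at all, compared with a plain hydrogen. Also open, from the compounds shown here alone, is how the tetrazole would fare with the opposite configuration at this carbon, or on the 2-hydroxyphenyl series of compound 1.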